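Notes on the shared core: amide in place of the ketone

The compounds below may be only part of what the source reports. "The series", "measured", "known", "first", "only" and "open" are said of these compounds alone.

Within the data shown here, compound 1 `COc1cc(-c2nnc(SCC(=O)c3ccc(Br)cc3)n2N)cc(OC)c1OC` gives 9230 nM in a functional assay on HCT-116 cells (Homo sapiens) for antiproliferative activity, read by MTT assay, with a stated time of 48 h (a higher number here means a weaker inhibitor, a lower number a stronger inhibitor), the highest number among the three measured members. Compound 2 `COc1cc(-c2nnc(SCC(=O)c3ccc(C)cc3)n2N)cc(OC)c1OC` gives 370 nM and compound 3 `COc1cc(-c2nnc(SCC(=O)Nc3ccccc3)n2N)cc(OC)c1OC` gives 1730 nM. The move of interest leads to compound 4 `COc1cc(-c2nnc(SCC(=O)NCc3ccc(C)cc3)n2N)cc(OC)c1OC`, which is not yet measured: (4-methylbenzyl)amino in place of 4-bromophenyl on a carbonyl carbon. Among the measured compounds shown here, two measured steps bear on it. Replacing bromo with methyl on the aromatic carbon gave a 25-fold lower number from compound 1 to compound 2 (1.40 log units; beyond the scatter), and replacing the 4-bromophenyl ketone with an anilino amide gave a 5.3-fold lower number from compound 1 to compound 3 (0.73 log units; beyond the scatter). Against this, the step to the amide from the methyl compound gave a 4.7-fold higher number from compound 2 to compound 3 (0.67 log units; beyond the scatter), so the amide does not carry the full benefit of the methyl. For the measured compounds named here, compound 4 combines both the methyl and an amide, though as a benzyl amide rather than an anilide, and there is no measured step for that extra saturated chain carbon. A step of a 6.2-fold lower number from compound 1 to compound 4 (0.79 log units; beyond the scatter) is therefore expected, downward and beyond the scatter. Compound 4 is estimated at 1500 nM, with a range from 400 nM to 6000 nM.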

Compound 4, half-maximal inhibitory concentration: > 100000 nM
Compound 4 gave a limit, no number (the forecaster's own chance of this, stated with the estimate: 5%); middle value at least 66-fold (1.82 log units) from the limit.
By their numbers in this assay, from the lowest: compound 2; then compound 3; then compound 1. At a limit, above all of these: compound 4.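

In this assay compound 4 gives > 100000 nM and this value is a limit, not a number. Even so, the steps are large: an at least 57-fold higher number from compound 3 to compound 4 (1.76 log units; beyond the scatter) for 4-methylbenzyl in place of phenyl on the amide-type nitrogen, while an at least 10-fold higher number from compound 1 to compound 4 (1.03 log units; beyond the scatter) and an at least 270-fold higher number from compound 2 to compound 4 (2.43 log units; beyond the scatter) mark the change on the carbonyl carbon. The earlier compounds shown here showed that this position accepted both a 4-methylphenyl ketone and an anilino amide with a measurable number, whereas these steps show that neither the methyl nor the amide carbonyl secures one when (4-methylbenzyl)amino sits on the carbonyl carbon.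

On these data alone, whether the loss follows the saturated chain carbon or the ring methyl remains open; plain benzylamino and 4-methylanilino groups on the carbonyl carbon would separate the two. As far as these compounds go, how a longer chain ending in an amine or a carboxylic acid would read also remains open.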